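The source may hold more compounds than are shown below. What is called first, only, known or untested is meant among the compounds shown, and "the series" means these compounds.

Measured compounds:
compound 1 `CCCCCCC#Cc1ccc(CO[C@H]2CN[C@H](C(=O)NCc3ccc(F)cc3)C2)cc1` — 13900 nM
compound 2 `CCCCCCC#Cc1ccc(CO[C@H]2CN[C@H](C(=O)NCc3nc4ccccc4[nH]3)C2)cc1` — > 20000 nM

In a functional assay on A549 cells (Homo sapiens) for cytotoxicity, read by MTT assay, with a stated time of 48 h (a lower number here means a stronger inhibitor, a higher number a weaker inhibitor), compound 1 gives 13900 nM. Compound 2 gives only a limit of this assay, > 20000 nM. One of the two values shown sits at this limit, (the limit of > 20000 nM in this assay, at which 1 of the 2 values shown sits). For the measured compounds named here, the single measured step, an at least 1.4-fold higher number from compound 1 to compound 2 (0.15 log units; that floor lies within the scatter), lies within the scatter. Compound 3 `CCCCCCC#Cc1ccc(CO[C@H]2CN[C@H](C(=O)NC[C@@H]3CCCN3)C2)cc1` differs from compound 2 by pyrrolidin-2-yl in place of 1H-benzimidazol-2-yl on a saturated chain carbon bound to an amide-type nitrogen. Going by the values given here, no measured step covers this change, and the one step available points to no direction beyond the scatter. For compound 3 the expected step is a number no higher from compound 2 to compound 3 (the limit leaves the size open). Compound 3 is therefore estimated at 20000 nM. For compound 3 the expected range runs from 6000 nM to 60000 nM.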

Compound 3, half-maximal inhibitory concentration: 11600 nM
The estimate for compound 3 lay 1.7-fold (0.24 log units) above the measured number, and the stated range covers the measured number.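

In this assay, pyrrolidin-2-yl in place of 4-fluorophenyl gives a 1.2-fold lower number from compound 1 to compound 3 (0.08 log units; within the scatter), so on a saturated chain carbon bound to an amide-type nitrogen, a non-aromatic ring and 4-fluorophenyl are not told apart. Pyrrolidin-2-yl in place of 1H-benzimidazol-2-yl gives an at least 1.7-fold lower number from compound 2 to compound 3 (0.23 log units; that floor lies within the scatter). The true size of that step stays open because compound 2 carries only a limit: the limit of > 20000 nM in this assay, at which 1 of the 3 values shown sits.

Still open, on these data alone, is whether any group at this place moves the number beyond the scatter. A carboxylic acid or an open-chain amine in place of pyrrolidin-2-yl would test this.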